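Nitro in Place of Methyl: From Compound 2 to Compound 4

The source may hold more compounds than are shown below. What is called first, only, known or untested is meant among the compounds shown, and "the series" means these compounds.

Of the compounds shown here, three have so far been measured in a functional assay for inhibition, read by spectrophotometry, with a stated time of 20 min, tested at 5 mg/mL; a higher number here means a stronger effect of the compound at the concentration tested, a lower number a weaker effect. Compound 1 `CC(=O)c1ccc(NC(=O)C(CC(C)C)N(C(=O)c2ccccc2)S(=O)(=O)c2ccc(C)cc2)cc1` gives 71.3%, and compound 3 `CC(=O)c1ccc(NC(=O)C(CC(C)C)N(C(=O)c2ccccc2)S(=O)(=O)c2ccc([N+](=O)[O-])cc2)cc1` gives 81.3%. Compound 2 `CC(=O)c1ccc(NC(=O)C2CC(O)CN2S(=O)(=O)c2ccc(C)cc2)cc1` gives 13%, the lowest of the three numbers; its gap to compound 1, the nearest of the other two, lies beyond the scatter, and its gap to compound 3 is larger still.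

Compound 4 `CC(=O)c1ccc(NC(=O)C2CC(O)CN2S(=O)(=O)c2ccc([N+](=O)[O-])cc2)cc1` has not yet been measured in this assay. It differs from compound 2 in one place: nitro in place of methyl on an aromatic carbon One measured step bears directly on this change. The same replacement, made on the core of compound 1, gave a number 10 percentage points higher from compound 1 to compound 3 (within the scatter), a step within the scatter. Within the data shown here, no other measured pair shares this change, so nothing else guides the expectation.

On that basis the step is expected to be small, a number 5 percentage points higher from compound 2 to compound 4 (within the scatter), with no movement beyond the scatter in this assay. Compound 4 is therefore estimated to give 18% in this assay, with a range from 5% to 35%.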

Compound 4, a percentage reported as inhibition, at one concentration (the size of the read-out at that concentration, not a potency): 70.7%
Compound 4: the middle estimate sits 52.7 percentage points below what was measured; the whole stated range lies below it.
By their numbers in this assay, from the lowest: compound 2; then compounds 4, 1 and 3 (each within the scatter of the next, the first and the last beyond it).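

In this assay, the replacement of methyl by nitro on the aromatic carbon, a step that stayed within the scatter on the core of compound 1, is large on the core of compound 2: a number 57.7 percentage points higher from compound 2 to compound 4 (beyond the scatter). The size of this replacement therefore depends on the core that carries it, and the step seen on one core does not carry over to the other: the same change on two cores in this assay, a number 10 percentage points higher (within the scatter) from compound 1 to compound 3 and a number 57.7 percentage points higher (beyond the scatter) from compound 2 to compound 4, 47.7 percentage points apart, beyond the scatter of two such steps The position on the 4-methylphenyl group, which had looked nearly silent in this series, can thus move the read-out far beyond the scatter, though the compounds shown demonstrate this on the core of compound 2 alone.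

On these data alone, with only methyl and nitro at this position on each core, it remains open whether the large step belongs to nitro alone or would also appear with another group there, such as an amine, a carboxylic acid or a nitrile. Which of the several places where the two cores differ sets the size of the step also stays open.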